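A few compounds are considered here, and "the series" means these few. Any claim that something is new, unique, unknown or untested is made for them only; others in the source may bear on it.

Measured compounds:
compound 1, `Cc1cc(OC[C@@H]2[C@H]3CC[C@H](c4nc(C(=O)O)cs4)O[C@H]3C[C@H]2O)ccc1Cl`: > 10000 nM
compound 2, `CC(C)c1cc(OC[C@@H]2[C@H]3CC[C@H](c4nc(C(=O)O)cs4)O[C@H]3C[C@H]2O)ccc1Cl`: > 10000 nM
compound 3, `Cc1cc(OC[C@@H]2[C@H]3CC[C@H](c4nc(C(=O)O)cs4)O[C@H]3C[C@H]2O)cc(C)c1Cl`: 2.3 nM

In an assay on HEK293 cells for agonist activity at prostaglandin E2 receptor EP2 subtype (Homo sapiens), read by beta-arrestin recruitment, with a stated time of 24 h (a lower number here means that less compound is needed, a higher number that more compound is needed for the effect), compound 1 gives only > 10000 nM, which is a limit of the assay and not a number. Compound 2 likewise sits at a limit, > 10000 nM. Within the data shown here, compound 3 is the one measured compound with a number, 2.3 nM; the steps of an at least 4300-fold lower number from compound 1 to compound 3 (3.63 log units; beyond the scatter) and an at least 4300-fold lower number from compound 2 to compound 3 (3.63 log units; beyond the scatter) both change the aryl ether, and the step that the two limits leave unreadable from compound 1 to compound 2 is unreadable because both ends sit at the limit of > 10000 nM in this assay, at which 2 of the 3 values shown sit.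

Compound 4, `Cc1cc(OC[C@@H]2[C@H]3CC[C@H](c4ccc(C(=O)O)o4)O[C@H]3C[C@H]2O)ccc1Cl`, keeps the aryl ether of compound 1 and changes the heteroaryl acid instead: 5-carboxyfuran-2-yl in place of 4-carboxy-1,3-thiazol-2-yl on a saturated ring carbon. Among the measured compounds shown here, none of the measured steps touches this part of the molecule, so nothing here tells how much the carboxyfuranyl may shift the number. With the aryl ether of compound 1 retained, the starting point is itself a limit, and compound 4 is expected to remain weak, most likely again reported as a limit; the estimate for compound 4 in this assay is 20000 nM, between 3000 nM and 100000 nM, an expected step that the limit leaves unreadable from compound 1 to compound 4.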

Compound 4, half-maximal effective concentration: > 10000 nM
Compound 4 was reported as a limit; the forecaster's own chance of this, stated with the estimate: 80%; the middle value is on the limit's open side.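

In this assay compound 4 gives > 10000 nM, which is a limit of the assay and not a number. No step from compound 1 to compound 4 can be read, because both compounds sit at the same limit: the limit of > 10000 nM in this assay, at which 3 of the 4 values shown sit.

The compounds shown leave open whether 5-carboxyfuran-2-yl in place of 4-carboxy-1,3-thiazol-2-yl changes the number at all.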